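A Second Chloro Group at the Assay Limit

This account rests on a few compounds, and the source may have more. Where it says the series, first, only, none or still open, it means among the compounds named here.

This series is tested in a functional assay on B16 cells (Mus musculus) for antiproliferative activity, read by MTT assay, with a stated time of 72 h; on this read-out higher numbers stand for weaker inhibition and lower numbers for stronger inhibition. The parent, compound 1 (`COc1cc(/C(=C/c2ccccc2)C(C)O)cc(OC)c1OC`), gives > 100000 nM, which is a limit and not a number. Compound 2 (`COc1cc(/C(=C/c2ccc(Cl)cc2)C(C)O)cc(OC)c1OC`), which carries a chloro group, gives > 100000 nM, also a limit. Compound 3 (`COc1cc(/C(=C/c2ccc([N+](=O)[O-])cc2)C(C)O)cc(OC)c1OC`), which carries a nitro group, gives > 100000 nM, again a limit. Compound 2 therefore has no exact position, and all the data sit together: the limit of > 100000 nM in this assay, at which 3 of the 3 values shown sit.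

Compound 4 (`COc1cc(/C(=C/c2ccc(Cl)c(Cl)c2)C(C)O)cc(OC)c1OC`) goes from 4-chlorophenyl to 3,4-dichlorophenyl: chloro in place of hydrogen on an aromatic carbon. Going by the values given here, the closest precedent for adding a chloro group is a step that the two limits leave unreadable from compound 1 to compound 2. The other two measured changes on this ring are a step that the two limits leave unreadable from compound 1 to compound 3 and a step that the two limits leave unreadable from compound 2 to compound 3. None of these steps has a readable size, so they give no support for expecting a shift in either direction beyond the scatter.

The expected step is a number no higher from compound 2 to compound 4 (the limit leaves the size open). The estimate for compound 4 is 100000 nM, with an expected range from 40000 nM to 200000 nM.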

Compound 4, half-maximal inhibitory concentration: 51500 nM
Estimate against measurement, compound 4: 1.9-fold (0.29 log units) above, within the range that was stated.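

Compound 4 is the only compound shown with an exact number in this assay, so a chloro group at this place, ortho to the existing chloro group, gives the series its first reading inside the range of the assay. The second chloro group gives an at least 1.9-fold lower number from compound 2 to compound 4 (0.28 log units; that floor lies within the scatter), and the full change from the parent gives an at least 1.9-fold lower number from compound 1 to compound 4 (0.28 log units; that floor lies within the scatter). Both are minimum sizes rather than true sizes, the earlier steps among the other compounds cannot be read at all, and the comparison rests on a single exact value: the limit of > 100000 nM in this assay, at which 3 of the 4 values shown sit.

From the compounds shown here alone, how far compound 4 truly lies from compound 2 stays open. Also open, going by these compounds, is whether a single chloro group at this place would be enough, and whether an amine or a carboxylic acid there would give a readable number in this assay.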